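Chloro to methyl on the aryl group of compound 1

This account rests on a few compounds, and the source may have more. Where it says the series, first, only, none or still open, it means among the compounds named here.

Of the compounds shown here, three have been measured in an assay on CHO cells for displacement of a labelled ligand from adenosine receptor A3 (Homo sapiens), read by scintillation counting, with a stated time of 3 h; on this read-out higher numbers stand for weaker inhibition and lower numbers for stronger inhibition. Compound 1 `Cn1c(-c2cccc(Cl)c2)nc2c(NC3CCCC3)ncnc21` gives 514 nM in this assay. Of the three numbers this is the second highest. The nearest is compound 3 `Cn1c(-c2ccccc2)nc2c(NC3CCC3)ncnc21`, which gives 280 nM in this assay; the two values lie within the scatter of each other, so no order between compound 1 and compound 3 can be read from them. The furthest is compound 2 `CCn1c(-c2ccccc2)nc2c(N)ncnc21`, which gives 5780 nM in this assay; its number is well beyond the scatter from that of compound 1, so compound 2 shows the weaker inhibition of the two.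

Compound 4 `Cc1cccc(-c2nc3c(NC4CCCC4)ncnc3n2C)c1` has not yet been measured. It differs from compound 1 in one place: methyl in place of chloro on an aromatic carbon. For the measured compounds named here, no pair of measured compounds carries a step of this kind, so the expectation rests on compound 1 alone. A group of the same size enters where chloro leaves, and the step from compound 1 to compound 4 in this assay is expected to be a 1.0-fold higher number from compound 1 to compound 4 (0.01 log units; within the scatter), that is, no change beyond the scatter in either direction. For compound 4 the value in this assay is estimated at 520 nM, with a range from 200 nM to 1400 nM.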

Compound 4, inhibition constant: 510 nM
Beside the measured number, compound 4's estimate is 1.0-fold (0.01 log units) above it; measured number inside the range.
By their numbers in this assay, from the lowest: compounds 3, 4 and 1 (each within the scatter of the next); then compound 2.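

In this assay, the change from 3-chlorophenyl to 3-methylphenyl gives a 1.0-fold lower number from compound 1 to compound 4 (0.00 log units; within the scatter), so at this place on the aromatic ring, meta to a large group, chloro and methyl cannot be told apart by this read-out. For the compounds shown here, this is the first step that changes a single place while the rest of the structure stays fixed, which the earlier compounds, with no such step among them, could not provide. Nothing available here accounts for the two groups reading alike.

Going by these compounds alone, the comparison covers only two groups of one heavy atom each, so it remains open whether the same flat reading would hold for a methoxy group, an amine, a carboxylic acid or a longer chain at this place. As far as these compounds go, it is also open whether the swap of chloro for methyl would read the same at other places on this ring, or with a different group on the amino nitrogen of the shared core.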